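Meta-substituted aryl groups on a nitro-bearing fused core

The compounds below may be only part of what the source reports. "The series", "measured", "known", "first", "only" and "open" are said of these compounds alone.

Working notes on three measured compounds sharing one core, differing only in the aryl group attached to the fused ring system. Compound 1 `Cn1cncc1C(O)(c1ccc(C#N)cc1)c1cc2cc([N+](=O)[O-])cc(-c3cccc(C#N)c3)c2o1` carries 3-cyanophenyl; in a functional assay on QG-56 cells (Homo sapiens) for antiproliferative activity (a lower number here means a stronger inhibitor, a higher number a weaker inhibitor), compound 1 gives 22.9 nM. Compound 2 `COc1cccc(-c2cc([N+](=O)[O-])cc3cc(C(O)(c4ccc(C#N)cc4)c4cncn4C)oc23)c1` carries 3-methoxyphenyl and gives 38.8 nM; the gap is small, a 1.7-fold higher number from compound 1 to compound 2 (0.23 log units; within the scatter). Compound 3 `Cn1cncc1C(O)(c1ccc(C#N)cc1)c1cc2cc([N+](=O)[O-])cc(-c3ccc(F)cc3)c2o1` carries 4-fluorophenyl and gives 158 nM, the highest of the three numbers; the nearest is compound 2, a 4.1-fold higher number from compound 2 to compound 3 (0.61 log units; beyond the scatter), the furthest compound 1, a 6.9-fold higher number from compound 1 to compound 3 (0.84 log units; beyond the scatter).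

Compound 4 `Cc1cccc(-c2cc([N+](=O)[O-])cc3cc(C(O)(c4ccc(C#N)cc4)c4cncn4C)oc23)c1` differs from compound 3 in one place: 3-methylphenyl in place of 4-fluorophenyl on an aromatic carbon. Both steps leading into compound 3 bear on this change, since each replaced 3-cyanophenyl or 3-methoxyphenyl with 4-fluorophenyl and raised the number beyond the scatter. Returning to a phenyl substituted in the manner of compound 1 and compound 2 is therefore expected to lower the number, by roughly the reverse of the step from compound 2 to compound 3, though no methyl analogue has been measured. Compound 4 is expected at 50 nM, with a range of 20 nM to 150 nM. The expected change is a 3.2-fold lower number from compound 3 to compound 4 (0.50 log units; beyond the scatter).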

Compound 4, half-maximal inhibitory concentration: 23.2 nM
Compound 4: middle estimate off by 2.2-fold (0.33 log units), on the high side; low and high end bracket the measured number.
By their numbers in this assay, from the lowest: compounds 1, 4 and 2 (each within the scatter of the next); then compound 3.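

Replacing 4-fluorophenyl with 3-methylphenyl on the shared core (a 6.8-fold lower number from compound 3 to compound 4 (0.83 log units; beyond the scatter)) brings the number back into the range of the other two compounds. A plain methyl group serves as well here as the nitrile or the methoxy (a 1.0-fold higher number from compound 1 to compound 4 (0.01 log units; within the scatter) and a 1.7-fold lower number from compound 2 to compound 4 (0.22 log units; within the scatter)), so in this assay neither of those two groups is needed for the lower numbers, and the three 3-substituted phenyl compounds cannot be ranked against each other. No measurement on hand explains the difference between 3-methylphenyl and 4-fluorophenyl.

Still open, as far as these compounds go, is whether the higher number of compound 3 goes with the fluorine itself or with where the substituent sits on the phenyl ring, as the two change together in every step into compound 3. Also open, from the compounds shown here alone, is how far this tolerance extends, for instance to an amine, a carboxylic acid or a longer chain on that phenyl ring.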